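A Methyl-Isoxazole Replaces the Sulfonamide on the Core

This account rests on a few compounds, and the source may have more. Where it says the series, first, only, none or still open, it means among the compounds named here.

Compound 1, `CCCS(=O)(=O)Nc1cccc2c1CCC2c1ncc[nH]1`: > 10000 nM
Compound 2, `c1cc(-c2nccs2)c2c(c1)C(c1ncc[nH]1)CC2`: 3190 nM
Compound 3, `Cn1cc(-c2cccc3c2CCC3c2ncc[nH]2)cn1`: > 10000 nM

In a functional assay on CHO cells for agonist activity at Alpha-1D adrenergic receptor (Homo sapiens), read by FLIPR and calcium flux (on this read-out lower numbers stand for an effect already at smaller amounts and higher numbers for an effect only at larger amounts of compound), compound 1 gives > 10000 nM, which is a limit of the assay and not a measured number. Compound 1 therefore stands only at a limit, and it is not alone there, since (the limit of > 10000 nM in this assay, at which 2 of the 3 values shown sit). Compound 2 gives 3190 nM in this assay. Compound 3 gives > 10000 nM in this assay; this value is again a limit.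

Compound 4 is `Cc1oncc1-c1cccc2c1CCC2c1ncc[nH]1` and has not yet been measured in this assay. It differs from compound 1 in one place: 5-methyl-1,2-oxazol-4-yl in place of (propylsulfonyl)amino on an aromatic carbon. A group with no ring, carrying 1 hydrogen-bond donor, leaves; one five-membered aromatic ring with 2 hetero atoms and no donor enters at the same aromatic carbon.

Two measured steps resemble this change. Putting a five-membered aromatic ring in that place once helped: an at least 3.1-fold lower number from compound 1 to compound 2 (0.49 log units; beyond the scatter). The other such ring left the outcome unreadable: a step that the two limits leave unreadable from compound 1 to compound 3, and between the two rings an at least 3.1-fold higher number from compound 2 to compound 3 (0.49 log units; beyond the scatter). The expected outcome for compound 4 is thus uncertain and most likely modest at best: an at least 1.2-fold lower number from compound 1 to compound 4 (0.09 log units; that floor lies within the scatter). Compound 4 is estimated at 8000 nM, within 2500 nM to 30000 nM, with a real chance that only a limit is reported.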

Compound 4, half-maximal effective concentration: > 10000 nM
Compound 4 ended at the assay's limit; the forecaster's own chance of this, stated with the estimate: 55%; middle value at least 1.2-fold (0.09 log units) from the limit.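

In this assay, exchanging the 1,3-thiazol-2-yl group for 5-methyl-1,2-oxazol-4-yl on the same aromatic carbon gives an at least 3.1-fold higher number from compound 2 to compound 4 (0.49 log units; beyond the scatter). Having a five-membered aromatic ring in this place is therefore not enough on its own: of the three such rings shown, only the 1,3-thiazol-2-yl group of compound 2 gives a measured number, while compound 3 and compound 4 go against any rule covering all such rings. The steps from compound 1 and from compound 3 to compound 4 cannot be read, since each joins two limits, and this limit now holds most of the compounds shown: the limit of > 10000 nM in this assay, at which 3 of the 4 values shown sit.

On these data alone, how far compound 1, compound 3 and compound 4 lie beyond that limit remains open, so their order among themselves is unknown. Also open, as far as these compounds go, is which feature of the 1,3-thiazol-2-yl group matters, something a 1,3-oxazol-2-yl group or a plain phenyl ring on the same aromatic carbon could help to test.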